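A few compounds are considered here, and "the series" means these few. Any claim that something is new, unique, unknown or untested is made for them only; others in the source may bear on it.

Measured in a toxicity assay on NIH3T3 cells (Mus musculus) for cytotoxicity, read by resazurin assay; on this read-out lower numbers stand for an effect already at smaller amounts and higher numbers for an effect only at larger amounts of compound:

- compound 1 `COC(=O)c1ccc(NCc2cncn2Cc2ccc(N)cc2)cc1-c1ccccc1`: > 10000 nM (a limit of the assay, not a number)
- compound 2 `COC(=O)c1ccc(NCc2cncn2Cc2ccccc2F)cc1-c1ccccc1`: "not determined" (no result reported)
- compound 3 `COC(=O)c1ccc(NCc2cncn2Cc2ccc(C(C)(C)C)cc2)cc1-c1ccccc1`: "not determined" (no result reported)

These three compounds share one core and differ in the group on the benzyl end. Compound 3 has no number of its own in this assay, so it offers no starting value for a comparison. Of the three entries, only compound 1 has a reported result, and that result is a limit: the limit of > 10000 nM in this assay, at which 1 of the 3 values shown sits.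

The next compound is compound 4 `COC(=O)c1ccc(NCc2cncn2Cc2ccccc2[N+](=O)[O-])cc1-c1ccccc1`, which has not yet been measured. The change is 2-nitrophenyl in place of 4-(tert-butyl)phenyl on a saturated chain carbon bound to an aromatic nitrogen, with 2-nitrophenyl in place of 4-(tert-butyl)phenyl on a saturated chain carbon bound to an aromatic nitrogen.

Within the data shown here, no measured step shows what a swap of this kind does here. The expectation is therefore for no step beyond the usual scatter in this assay, and for a result in the same high region as compound 1, quite possibly reported only as a limit. Compound 4 is expected at about 20000 nM, with an estimated range of 5000 nM to 60000 nM.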

Compound 4, half-maximal effective concentration: 10000 nM
Estimate against measurement, compound 4: 2.0-fold (0.30 log units) above; the range from low to high includes it.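

In this assay, among these compounds, compound 4 gives 10000 nM as the first actual number, so 2-nitrophenyl on the saturated chain carbon bound to an aromatic nitrogen yields a readable value. Compound 1, with 4-aminophenyl at the same place, has only a limit of the assay: the limit of > 10000 nM in this assay, at which 1 of the 4 values shown sits. The comparison reads a number no higher from compound 1 to compound 4 (the limit leaves the size open) and, as the limit leaves its size unreadable, these two compounds cannot show how much this change matters.

With no number shown for compound 2 or compound 3, the effect of 2-nitrophenyl in place of 4-(tert-butyl)phenyl remains unknown. Also open, as far as these compounds go, is how this read-out would respond to a carboxylic acid, a primary amide or a longer alkyl chain at this place.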